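Trifluoromethyl gives way to methoxy in compound 3

The source may report more compounds than this note shows. Statements on the series, on what has been measured and on what is new or still open speak of the compounds shown alone.

compound 1 `CCNC(=O)Nc1sc2ccccc2c1C(=O)N1CCN(C2CCN(C(=O)OC(C)(C)C(F)(F)F)CC2)CC1` gives 5%
compound 2 `CCNC(=O)Nc1sc2cc(C)ccc2c1C(=O)N1CCN(C2CCN(C(=O)C(C)(C)CF)CC2)CC1` gives 84%
compound 3 `CCNC(=O)Nc1sc2cc(C(F)(F)F)ccc2c1C(=O)N1CCN(C2CCN(C(=O)C(C)(C)C(F)(F)F)CC2)CC1` gives 7%

In an ADME assay on microsomes from liver (Homo sapiens) for metabolic stability, read by LC-MS, with a stated time of 15 min (on this read-out higher numbers stand for a more stable compound and lower numbers for a less stable compound), compound 3 gives 7% and lies within the scatter of compound 1 with 5% while compound 2 with 84% stands far higher, beyond the scatter. Compound 4 `CCNC(=O)Nc1sc2cc(OC)ccc2c1C(=O)N1CCN(C2CCN(C(=O)C(C)(C)C(F)(F)F)CC2)CC1` departs from compound 3 in one place methoxy in place of trifluoromethyl on an aromatic carbon with methoxy in place of trifluoromethyl on an aromatic carbon. For the measured compounds named here, no two measured compounds differ in one place only, so no measured step speaks directly to this change. Going by the values given here, compound 3 and compound 2 differ in more than one place, and compound 2 with 84% shows only that a high number is possible on the shared core. A small upward step is therefore expected, probably not beyond the scatter, though a larger rise cannot be excluded. The estimated step is a number 8 percentage points higher from compound 3 to compound 4 (within the scatter) in this assay on this reading. Compound 4 is estimated at 15% with an expected range from 3% to 45% in this measurement.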

Compound 4, percent of the compound remaining: 29%
Compound 4: middle estimate off by 14 percentage points, on the low side; low and high end bracket the measured number.
By their numbers in this assay, from the lowest: compounds 1 and 3 (each within the scatter of the next); then compound 4; then compound 2.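

In this assay, methoxy in place of trifluoromethyl on an aromatic carbon gives a number 22 percentage points higher from compound 3 to compound 4 (beyond the scatter), the first change in one place among the compounds shown. This shows that the group at this place, meta to a fused ring and para to a fused ring, can by itself move the number on the shared core with everything else held fixed. Nothing given here explains the rise, which remains a single step on one background.

Going by these compounds, whether the same change would give a similar step on another background remains open, as does the question of whether the rise belongs to methoxy in particular or comes with the loss of trifluoromethyl. A chlorine atom, a nitrile or a longer ether chain at this place could help separate those two readings.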